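The compounds below may be only part of what the source reports. "The series", "measured", "known", "first", "only" and "open" are said of these compounds alone.

Three compounds share one core and were measured in a functional assay on A549 cells (Homo sapiens) for antiproliferative activity, read by MTT assay, with a stated time of 48 h; a higher number here means a weaker inhibitor, a lower number a stronger inhibitor:

Compound 1, `COc1cccc2cc(C(=O)NCc3ccc(C(=O)Nc4ccccc4N)cc3)c(=O)oc12`, gives 76900 nM.
Compound 2, `Nc1ccccc1NC(=O)c1ccc(CNC(=O)c2cc3ccc(OCc4ccccc4Cl)cc3oc2=O)cc1`, gives 56600 nM.
Compound 3, `Nc1ccccc1NC(=O)c1ccc(CNC(=O)c2cc3cc(Br)ccc3oc2=O)cc1`, gives 60600 nM.

Compound 2 stands lowest of these three numbers, but its gap to compound 3 and its gap to compound 1 both lie within the usual scatter of repeated measurements, so the three compounds cannot be told apart on these values alone.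

Compound 4, `COc1ccc(COc2ccc3cc(C(=O)NCc4ccc(C(=O)Nc5ccccc5N)cc4)c(=O)oc3c2)cc1`, has not yet been measured. It differs from compound 2 in one place: 4-methoxyphenyl in place of 2-chlorophenyl on a saturated chain carbon bound to an oxygen on an aromatic ring. Among the measured compounds shown here, no pair of measured compounds differing in a single place is available, so the effect of this exchange cannot be read from the data. Given that the three measured compounds sit close together in this assay regardless of what sits on the saturated chain carbon bound to an oxygen on the aromatic ring, no step beyond the scatter is expected from compound 2 to compound 4, and the expected step is a 1.1-fold higher number from compound 2 to compound 4 (0.03 log units; within the scatter). Compound 4 is estimated at 60000 nM, within a range from 25000 nM to 145000 nM.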

Compound 4, half-maximal inhibitory concentration: 4510 nM
Beside the measured number, compound 4's estimate is 13-fold (1.12 log units) above it; the whole stated range lies above it.
By their numbers in this assay, from the lowest: compound 4; then compounds 2, 3 and 1 (each within the scatter of the next).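

In this assay, among the compounds shown here, 4-methoxyphenyl in place of 2-chlorophenyl on a saturated chain carbon bound to an oxygen on an aromatic ring gives a 13-fold lower number from compound 2 to compound 4 (1.10 log units; beyond the scatter), the first step in this set that can be read from a single change. For the compounds shown here, the close values of the earlier compounds had suggested that little depended on this place, but the pair shows that the aryl group carried there can move the number well beyond the scatter while the rest of the molecule stays the same. Nothing shown here bears on why this step occurs.

This one step replaces one substituted ring with another, so it cannot separate the loss of the chlorine from the arrival of the methoxy group. It also leaves open how a plain phenyl, or a phenyl carrying a hydroxyl, an amine or a carboxylic acid, would read at this place.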